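The source may report more compounds than this note shows. Statements on the series, on what has been measured and on what is new or still open speak of the compounds shown alone.

Measured so far:
compound 1 `Fc1cccc(F)c1-c1nc2cccnc2o1` — 50%
compound 2 `O=[N+]([O-])c1ccccc1-c1nc2cccnc2o1` — 57%

In a functional assay on the whole organism for inhibition, with Rattus norvegicus as the target, at a dose of 30 mg/kg (on this read-out lower numbers stand for less inhibition and higher numbers for more inhibition at the one dose given (going by the name of the read-out)), compound 2 gives 57%. Compound 1 gives 50% in the same read-out, and the two numbers lie within the usual scatter of each other, so no order between them is claimed; compound 2 simply stands at the upper of the two values shown. For the measured compounds named here, no step between measured compounds that differ in one place is available, so nothing in these two numbers shows how a change on the six-membered ring of carbon only moves the read-out.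

Compound 3 `Cc1ccccc1-c1nc2cccnc2o1` is not yet measured. It differs from compound 2 by methyl in place of nitro on an aromatic carbon.

Since compound 1 and compound 2 carry unlike groups at that ring and still fall within the scatter of each other, the expected step is a number 10 percentage points lower from compound 2 to compound 3 (within the scatter), that is, none beyond the scatter in either direction. Compound 3 is estimated at 47% in this assay, with a range from 27% to 67%.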

Compound 3, a percentage reported as inhibition, in the whole organism at one dose (the size of the read-out at that dose, not a potency): 3%
Beside the measured number, compound 3's estimate is 44 percentage points above it; measured number below the stated range.
By their numbers in this assay, from the lowest: compound 3; then compounds 1 and 2 (each within the scatter of the next).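

In this assay, methyl in place of nitro on an aromatic carbon of the six-membered aromatic ring of carbon only gives a number 54 percentage points lower from compound 2 to compound 3 (beyond the scatter), so the read-out is not indifferent to the group at this position, which the two earlier values, lying within the scatter of each other, could not show. Nitro brings 3 heavy atoms and 2 hydrogen-bond acceptors, methyl brings 1 heavy atom and no hydrogen-bond acceptors, and this single pair cannot separate these differences from one another. No measurement among the compounds shown bears on what lies behind this step.

As far as these compounds go, it remains open whether an amine, a methoxy group or a carboxylic acid at this position would keep the read-out close to that of compound 2 or leave it close to that of compound 3. The step also rests on one matched pair at a single dose, so whether the same change has a similar effect on other substituted versions of the shared core, or at other doses, remains unsettled.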